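Chain Extension and an Aryl Replacement in Dithioacetal Diacids

The source may hold more compounds than are shown below. What is called first, only, known or untested is meant among the compounds shown, and "the series" means these compounds.

Measured compounds:
compound 1, `CCCCCCCCc1ccccc1C(SCCC(=O)O)SCCC(=O)O`, gives 5670 nM in an assay on membranes from lung (Cavia porcellus) for binding affinity to cysteinyl leukotriene receptor (Homo sapiens); on this read-out higher numbers stand for weaker inhibition and lower numbers for stronger inhibition.
compound 2, `O=C(O)CCSC(SCCC(=O)O)c1ccccc1CCCCCCCCCCCC(F)(F)F`, gives 147 nM in this assay.

Compound 2 holds the lowest number of the two in this assay; its nearest neighbour is compound 1, separated by a 39-fold lower number from compound 1 to compound 2 (1.59 log units; beyond the scatter). That single step is the only one bearing on the move to compound 3, `CCCCc1ccc(CCCCc2ccccc2C(SCCC(=O)O)SCCC(=O)O)cc1`, whose change is 4-butylphenyl in place of 8,8,8-trifluorooctyl on a saturated chain carbon, four bonds along the chain from an aromatic carbon. Lengthening the chain on compound 1 gave the large gain seen in a 39-fold lower number from compound 1 to compound 2 (1.59 log units; beyond the scatter), and compound 3 keeps a comparably extended side chain, so a number near that of compound 2 is expected, with some allowance for the aromatic ring replacing the fluorinated chain end. Compound 3 is therefore estimated at 300 nM, within 80 nM to 1200 nM, an expected step of a 2.0-fold higher number from compound 2 to compound 3 (0.31 log units; beyond the scatter).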

Compound 3, inhibition constant: 4230 nM
The estimate for compound 3 lay 14-fold (1.15 log units) below the measured number, and the stated range ends below it.
By their numbers in this assay, from the lowest: compound 2; then compounds 3 and 1 (each within the scatter of the next).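

In this assay, a side chain of similar size does not by itself hold the gain at this position: the 4-butylphenyl group replaces the 8,8,8-trifluorooctyl group, and the result is a 29-fold higher number from compound 2 to compound 3 (1.46 log units; beyond the scatter). Set against the shorter-chained parent, 4-butylphenyl in place of butyl gives a 1.3-fold lower number from compound 1 to compound 3 (0.13 log units; within the scatter), so this extension, unlike the fluorinated chain of compound 2, leaves the number within the scatter of compound 1. Nothing measured here accounts for the difference between the two groups.

The compounds shown leave open whether the gain in compound 2 belongs to the length of its chain or to the trifluoromethyl end, and a dodecyl chain at this place would separate the two. A terminal phenyl on a saturated chain is also left open.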